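A few compounds are considered here, and "the series" means these few. Any claim that something is new, unique, unknown or untested is made for them only; others in the source may bear on it.

Measured so far in an ADME assay on MRC5 cells (Homo sapiens) for inhibition, with a stated time of 72 h; a lower number here means that less compound is needed, a higher number that more compound is needed for the effect:
compound 1 `CCc1ccccc1C(=O)Nc1c[nH]nc1C(=O)N[C@H]1CC[C@H](OC)CC1` — 3400 nM
compound 2 `CO[C@H]1CC[C@H](NC(=O)c2n[nH]cc2NC(=O)c2ncoc2-c2ccccc2)CC1` — 28000 nM
compound 3 `COc1cccc(OC)c1C(=O)Nc1c[nH]nc1C(=O)NC1CC2CCC1C2` — > 50000 nM

Compound 1 and compound 2 each give a number in this assay, so their potency can be compared directly. Compound 3 does not: in this assay compound 3 returns only a limit, > 50000 nM, and so stands at the limit of > 50000 nM in this assay, at which 1 of the 3 values shown sits, rather than at a measured number. What is known of compound 3 is therefore just that it is the weakest of the three values shown.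

Compound 4 `COc1cccc(OC)c1C(=O)Nc1c[nH]nc1C(=O)Nc1ccncc1` is not yet measured. It keeps the shared core and the same dimethoxyphenyl amide of compound 3, and differs only at the other amide: a group of 6 heavy atoms (5 carbon, 1 nitrogen; one six-membered aromatic ring with 1 hetero atom) in place of a group of 7 heavy atoms (7 carbon; 2 five-membered non-aromatic rings of carbon only), on an amide-type nitrogen.

Among the measured compounds shown here, with no measured pair that isolates this kind of change, there is little to anchor an expectation. Since compound 3 is already at a limit, the step from compound 3 to compound 4 is expected to be an at least 1.4-fold lower number from compound 3 to compound 4 (0.15 log units; that floor lies within the scatter) at most, and a limit again is quite possible. Compound 4 is expected to give about 35000 nM in this assay, within a range from 8000 nM to 50000 nM.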

Compound 4, half-maximal effective concentration: > 50000 nM
Compound 4: only a limit was reported (the forecaster's own chance of this, stated with the estimate: 50%); at least 1.4-fold (0.15 log units) between middle value and limit.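

Among the compounds shown here, compound 3 and compound 4 both return only a limit rather than a number, so no step between them can be read: the limit of > 50000 nM in this assay, at which 2 of the 4 values shown sit. The compounds shown leave open whether pyridin-4-yl in place of the group of carbon-only rings on this amide changes the value at all.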